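Chloro for Trifluoromethyl, Repeated on a Second Core

The compounds below may be only part of what the source reports. "The series", "measured", "known", "first", "only" and "open" are said of these compounds alone.

Compound 1, `CC(C)c1ccc(OC(Cc2ccc(C(F)(F)F)cc2)C(=O)O)cc1`, gives 10 mg/kg in a functional assay on the whole organism for inhibition, with Rattus norvegicus as the target; on this read-out lower numbers stand for an effect already at smaller amounts and higher numbers for an effect only at larger amounts of compound.
Compound 2, `CC(C)c1ccc(OC(Cc2ccc(Cl)cc2)C(=O)O)cc1`, gives 10 mg/kg in this assay.
Compound 3, `CC(C)c1ccc(OC(C)(Cc2cccc(C(F)(F)F)c2)C(=O)O)cc1`, gives 5 mg/kg in this assay.

Compound 1 and compound 2 share one core and differ in a single place, (chloro in place of trifluoromethyl on an aromatic carbon). The step they show in this assay is no change at the digits printed from compound 1 to compound 2 (within the scatter). Compound 3 carries a different core; how it differs from compound 1 is not broken down here. Its value in this assay lies within the usual scatter of both compound 1 and compound 2, so no order among the three can be read from these numbers.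

Compound 4, `CC(C)c1ccc(OC(C)(Cc2cccc(Cl)c2)C(=O)O)cc1`, is not yet measured. It stands to compound 3 as compound 2 stands to compound 1: chloro in place of trifluoromethyl on an aromatic carbon. This is the same kind of change, though the place is not identical, the chloro sitting meta to a large group here where in the earlier pair it sat para to a large group. Because no change at the digits printed from compound 1 to compound 2 (within the scatter) showed no change within the scatter, compound 4 is expected to show a step of no change at the digits printed from compound 3 to compound 4 (within the scatter) in this assay. The estimate for compound 4 is therefore 5 mg/kg, with a range from 2.5 mg/kg to 10 mg/kg.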

Compound 4, dose for half-maximal effect: 5 mg/kg
For compound 4 middle estimate and measured number coincide at the digits printed; low and high end bracket the measured number.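

In this assay the exchange of trifluoromethyl for chloro on the second core gives no change at the digits printed from compound 3 to compound 4 (within the scatter) and so matches what the same exchange gave on the first core. Across these two pairs the exchange therefore carries from one core to the other without a difference that can be told from the scatter: the same change on two cores in this assay, no change at the digits printed (within the scatter) from compound 1 to compound 2 and no change at the digits printed (within the scatter) from compound 3 to compound 4, 1.0-fold (0.00 log units) apart, within the scatter of two such steps. Going by these compounds alone, this rests on only two pairs in a single whole-organism read-out, the place on the aromatic ring is not the same in both, and the data neither separate the effect of the core from that of the place nor show that the exchange would leave the value unchanged on any further core.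

The compounds shown leave open how a bromo, a methoxy or a nitrile would read on that aromatic carbon in this assay. They also leave open what an amide or an ester in place of the carboxylic acid would give on either core.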